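The compounds below may be only part of what the source reports. "The series", "measured", "known", "first", "only" and "open" are said of these compounds alone.

Compound 2 `O=C1NC(=O)C(Cc2ccc(Oc3ccc(Cl)cc3)cc2)S1` shows the lowest number of the two measured in a functional assay for agonist activity at Free fatty acid receptor 1 (Homo sapiens), read by FLIPR, in the presence of a further agent that is not named here; on this read-out higher numbers stand for an effect only at larger amounts of compound and lower numbers for an effect already at smaller amounts: compound 2 gives 240 nM, while compound 1 `Cc1ccnc(Oc2ccc(CC3SC(=O)NC3=O)cc2)c1` gives 4280 nM. Among the measured compounds shown here, the only measured step, an 18-fold lower number from compound 1 to compound 2 (1.25 log units; beyond the scatter), changes the same group on the oxygen as the step now considered, (benzyl in place of 4-chlorophenyl on an oxygen on an aromatic ring), which leads to compound 3 `O=C1NC(=O)C(Cc2ccc(OCc3ccccc3)cc2)S1`. For the measured compounds named here, no measured step swaps an aryl for a benzyl here, so the direction is uncertain; a step within the scatter is expected, a 1.5-fold higher number from compound 2 to compound 3 (0.16 log units; within the scatter). For compound 3 in this assay the estimate is 350 nM, with a range from 90 nM to 1400 nM.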

Compound 3, half-maximal effective concentration: 6180 nM
Estimate against measurement, compound 3: 18-fold (1.25 log units) below; measured number above the stated range.
By their numbers in this assay, from the lowest: compound 2; then compounds 1 and 3 (each within the scatter of the next).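

On an oxygen on an aromatic ring, the group's identity proves decisive even at equal size: in this assay, benzyl in place of 4-chlorophenyl gives a 26-fold higher number from compound 2 to compound 3 (1.41 log units; beyond the scatter), although each group has 7 heavy atoms and one six-membered aromatic ring of carbon only. Benzyl and 4-methylpyridin-2-yl do not separate, with a 1.4-fold higher number from compound 1 to compound 3 (0.16 log units; within the scatter), so among these three groups only 4-chlorophenyl stands apart. Nothing available accounts for this gap. On these data alone, whether the chlorine or the added carbon of benzyl carries the step remains open; phenyl and 4-chlorobenzyl on the same oxygen would separate the two.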